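A few compounds are considered here, and "the series" means these few. Any claim that something is new, unique, unknown or untested is made for them only; others in the source may bear on it.

In a functional assay on HL-60 cells (Homo sapiens) for cytotoxicity, read by WST assay, with a stated time of 48 h (on this read-out higher numbers stand for an effect only at larger amounts of compound and lower numbers for an effect already at smaller amounts), compound 1 `O=C1OC[C@H](Cc2ccccc2)[C@H]1Cc1ccc(O)cc1` gives 88000 nM and compound 2 `Oc1ccccc1C[C@H]1COC[C@@H]1Cc1ccc(Cl)c(Cl)c1` gives 34000 nM. Compound 2 therefore holds the lower of the two numbers, and the gap between them lies beyond the scatter. These two compounds differ in more than one place, so no single structural change can be read from the pair. Compound 3 `Cc1ccc(C[C@H]2COC[C@@H]2Cc2ccc(Cl)c(Cl)c2)cc1` departs from compound 2 in one place, with 4-methylphenyl in place of 2-hydroxyphenyl on a saturated chain carbon bound to a saturated ring carbon. Among the compounds with values here, no measured pair shows what this change does, so the expectation starts from compound 2 at 34000 nM. In this assay, no step beyond the scatter is expected, and the estimated change is a 1.4-fold lower number from compound 2 to compound 3 (0.13 log units; within the scatter). The estimate for compound 3 is 25000 nM, with an expected range from 9000 nM to 70000 nM.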

Compound 3, half-maximal effective concentration: 21000 nM
Estimate against measurement, compound 3: 1.2-fold (0.08 log units) above; measured number inside the range.
By their numbers in this assay, from the lowest: compounds 3 and 2 (each within the scatter of the next); then compound 1.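

In this assay, within the data shown here, 4-methylphenyl in place of 2-hydroxyphenyl on a saturated chain carbon bound to a saturated ring carbon gives a 1.6-fold lower number from compound 2 to compound 3 (0.21 log units; within the scatter) as the first one-place comparison. The two compounds cannot be told apart on this read-out, so in this pair the hydrogen-bond donor and acceptor counted for 2-hydroxyphenyl are not required to hold the number at this level. No measurement at hand explains this result.

Still open, on these data alone, is whether any group at this place can move the number beyond the scatter, for example an amine, a carboxylic acid or a longer chain. Also open, as far as these compounds go, is whether the same change would read alike on a different core, such as that of compound 1.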